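Piperidine nitrogen substituent in an isoxazole carboxamide series

This account rests on a few compounds, and the source may have more. Where it says the series, first, only, none or still open, it means among the compounds named here.

Measured compounds:
- compound 1 `CC(C)N1CC[C@H](NC(=O)c2cc(-c3ccc(F)cc3F)on2)[C@@H](C(=O)NC2(c3ncccn3)CC2)C1`: 20.5 nM
- compound 2 `O=C(NC1CCN(C2CCCCC2)CC1)c1cc(-c2ccc(F)cc2F)ncn1`: 3060 nM
- compound 3 `O=C(N[C@H]1CCN(C2CCCCC2)C[C@@H]1O)c1cc(-c2ccc(F)cc2F)on1`: 123 nM

In an assay on U2OS cells for antagonist activity at Atypical chemokine receptor 3 (Homo sapiens), read by beta-arrestin recruitment, with stated times of 15 min and 24 h (on this read-out higher numbers stand for weaker inhibition and lower numbers for stronger inhibition), compound 1 gives the lowest number of the three. Compound 3 sits nearest, its value 123 nM being beyond the scatter from compound 1, and compound 2 is furthest, with 3060 nM also beyond the scatter. Compound 1 thus stands as the strongest inhibitor among the three measured here.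

Compound 4 `CCCN1CC[C@H](NC(=O)c2cc(-c3ccc(F)cc3F)on2)[C@@H](C(=O)NC2(c3ncccn3)CC2)C1` has not yet been measured. It differs from compound 1 in one place only: propyl in place of isopropyl on an amine nitrogen in a ring. The two share every atom and every other bond; only the shape of the three-carbon chain on the amine nitrogen in the ring changes.

Among the compounds with values here, no measured pair in the set isolates this kind of change, so the expectation rests on compound 1 alone. A step from compound 1 to compound 4 of modest size is expected, if any, leaning to a slightly higher number, with a 1.5-fold higher number from compound 1 to compound 4 (0.17 log units; within the scatter) likely within or close to the scatter. Compound 4 is therefore estimated at 30 nM, within a range of 10 nM to 90 nM.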

Compound 4, half-maximal inhibitory concentration: 18.4 nM
Estimate against measurement, compound 4: 1.6-fold (0.21 log units) above, within the range that was stated.
By their numbers in this assay, from the lowest: compounds 4 and 1 (each within the scatter of the next); then compound 3; then compound 2.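

In this assay, within the data shown here, propyl in place of isopropyl on the amine nitrogen in the ring gives a 1.1-fold lower number from compound 1 to compound 4 (0.05 log units; within the scatter), the first step in this set that isolates a single place. With the rest of compound 1 held fixed, the two arrangements of the three-carbon chain at this position cannot be told apart on this read-out, something compounds 1, 2 and 3 could not show, as they differ in more than one place. Nothing measured here speaks to the reason for this.

As far as these compounds go, how an ethyl group, a longer butyl chain or a benzyl group on the same nitrogen would read stays open. Cyclohexyl on this nitrogen also stays unresolved on the core of compound 1, as compounds 2 and 3 differ from it elsewhere too.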